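A few compounds are considered here, and "the series" means these few. Any claim that something is new, unique, unknown or untested is made for them only; others in the source may bear on it.

Compound 3 `CCC(CC)c1ccc2c(NCCCNCc3cccc(OC)c3O)ccnc2c1` in an ADME assay for permeability, using PAMPA, with a stated time of 30 min, at pH 7.4 (on this read-out higher numbers stand for higher permeability and lower numbers for lower permeability), gives 23 10^-6 cm/s, level at the digits printed with compound 2 `COc1cccc(CNCCCNc2ccnc3cc(CC(C)C)ccc23)c1O`, which gives 23 10^-6 cm/s; together these are the lowest of the three numbers, and the furthest is compound 1 `COc1cccc(CNCCCNc2ccnc3cc(Oc4cccc(N(C)C)c4)ccc23)c1O`, which gives 317 10^-6 cm/s. The step from compound 3 to compound 4 `COc1cccc(CNCCCNc2ccnc3cc(-c4cccc5ccccc45)ccc23)c1O` is naphthalen-1-yl in place of pentan-3-yl on an aromatic carbon. For the measured compounds named here, two measured steps bear on it: a 14-fold lower number from compound 1 to compound 3 (1.14 log units; beyond the scatter) and a 14-fold lower number from compound 1 to compound 2 (1.14 log units; beyond the scatter), each a large drop when an alkyl group stood in place of the 3-(dimethylamino)phenoxy group with its aromatic ring, while no change at the digits printed from compound 2 to compound 3 (within the scatter) shows that exchanging one alkyl group for another left the number unchanged. Compound 4 brings in a group of two six-membered aromatic rings of carbon only in place of pentan-3-yl, so the movement is expected to run back in the direction of compound 1, though the missing ether oxygen and dimethylamino group leave its size uncertain. The expected step is a 3.9-fold higher number from compound 3 to compound 4 (0.59 log units; beyond the scatter), giving compound 4 an estimated 90 10^-6 cm/s, with a range from 25 10^-6 cm/s to 320 10^-6 cm/s.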

Compound 4, apparent permeability: 237 10^-6 cm/s
The estimate for compound 4 lay 2.6-fold (0.42 log units) below the measured number, within the range that was stated.
By their numbers in this assay, from the lowest: compounds 2 and 3 (each within the scatter of the next); then compounds 4 and 1 (each within the scatter of the next).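

In this assay naphthalen-1-yl on this aromatic carbon gives a 10-fold higher number from compound 3 to compound 4 (1.01 log units; beyond the scatter) and a 10-fold higher number from compound 2 to compound 4 (1.01 log units; beyond the scatter) in comparison with the two alkyl groups. The same group stands level with the 3-(dimethylamino)phenoxy group, with a 1.3-fold lower number from compound 1 to compound 4 (0.13 log units; within the scatter) on this read-out, so a high number at this position does not require the ether oxygen or the dimethylamino group, since naphthalen-1-yl holds carbon only. Among these four compounds, the two with aromatic rings on this carbon stand apart from the two with alkyl groups, and none goes against that split.

The compounds shown leave open whether a single phenyl ring would reach the same level, or whether naphthalen-2-yl would match naphthalen-1-yl. They also leave open what an amine or a carboxylic acid on the naphthalene would do to the number, and no evidence at hand accounts for the split between the aromatic and alkyl groups.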